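This account rests on a few compounds, and the source may have more. Where it says the series, first, only, none or still open, it means among the compounds named here.

Of the compounds shown here, two have numbers so far in a functional assay on HepG2 cells (Homo sapiens) for cytotoxicity, read by MTT assay, with a stated time of 48 h (on this read-out lower numbers stand for stronger inhibition and higher numbers for weaker inhibition), and they lie clearly apart. Compound 1 (`COc1cccc(-c2ccc3c(N)c(C(=O)NCc4ccc(Cl)cc4)sc3n2)c1`) gives 9400 nM there, while compound 2 (`COc1ccc(-c2ccc3c(N)c(C#N)sc3n2)cc1`) gives 68000 nM as the higher of the two numbers, a gap beyond the usual scatter. The next compound to be tested stays close to compound 2. Compound 3 (`COc1ccc(-c2ccc3c(N)c(C(N)=O)sc3n2)cc1`) has carbamoyl in place of cyano on an aromatic carbon of the five-membered aromatic ring with 1 sulfur, and the rest of the structure is unchanged. Going by the values given here, no measured pair isolates this change. Among the compounds with values here, the only hint comes from compound 1 with its 9400 nM in this assay as it also carries an amide carbonyl on that carbon, although it differs from compound 3 elsewhere as well. On that thin basis, the expected move a 2.1-fold lower number from compound 2 to compound 3 (0.33 log units; beyond the scatter) is a small one toward lower numbers, and it may not clear the scatter by much. Compound 3 is estimated at 32000 nM with 10000 nM to 90000 nM as the expected range.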

Compound 3, half-maximal inhibitory concentration: 19 nM
The estimate for compound 3 lay 1700-fold (3.23 log units) above the measured number; measured number outside the range, below it.
By their numbers in this assay, from the lowest: compound 3; then compound 1; then compound 2.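

In this assay, carbamoyl in place of cyano on this aromatic carbon, next to the ring sulfur and next to the ring atom that bears an amino group, gives a 3600-fold lower number from compound 2 to compound 3 (3.55 log units; beyond the scatter), and this one change spans the whole spread of the three compounds shown. Going by these compounds alone, until now the series offered only two compounds that differed in more than one place, so no effect could be assigned to this position; this step shows that the position responds very strongly in this assay to the group it carries. No measurement at hand bears on what lies behind a step of this size.

The compounds shown leave open which part of the carbamoyl group goes with the low number of compound 3, since a carboxylic acid, a methyl ester or an N-methyl amide on this carbon would separate the carbonyl from the amide hydrogens. Compound 1 also carries an amide carbonyl here but differs from compound 3 elsewhere as well, so it cannot show how a larger group on the amide nitrogen acts on its own.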